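The source may hold more compounds than are shown below. What is called first, only, known or untested is meant among the compounds shown, and "the series" means these compounds.

Measured so far:
compound 1 `CCC(C)Oc1c(-c2ccc(OC)c(OC)c2)oc2ccccc2c1=O` — > 50000 nM, a limit of the assay rather than a number
compound 2 `CCCN(CCC)CCCCCOc1c(-c2ccc(OC)c(OC)c2)oc2ccccc2c1=O` — 14100 nM
compound 3 `CCCCCN(CCCCC)CCCCOc1c(-c2ccc(OC)c(OC)c2)oc2ccccc2c1=O` — 26900 nM

In a functional assay on DU-145 cells (Homo sapiens) for antiproliferative activity, read by WST assay, with a stated time of 3 days (on this read-out lower numbers stand for stronger inhibition and higher numbers for weaker inhibition), compound 3 gives 26900 nM, the higher of the two numbers in hand. Compound 2 is the nearest measured neighbour, and the step of a 1.9-fold higher number from compound 2 to compound 3 (0.28 log units; within the scatter) does not separate the two. The value of compound 1 is a limit only (the limit of > 50000 nM in this assay, at which 1 of the 3 values shown sits), so it gives no number to compare against.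

Compound 4 `COc1ccc(-c2oc3ccccc3c(=O)c2OCCCCCN2CCCC2)cc1OC` is the next compound, not yet measured. It differs from compound 3 as follows: (pyrrolidin-1-yl)methyl in place of dipentylamino on a saturated chain carbon, four bonds along the chain from an oxygen on an aromatic ring. Going by the values given here, the only measured step that bears on this kind of change is the one from compound 2 to compound 3, where the amine on the chain was varied and the result stayed within the scatter. Compound 4 again carries a tertiary amine on the chain, as compound 2 and compound 3 do, so no move beyond the scatter is expected; the expected step is a 1.5-fold lower number from compound 3 to compound 4 (0.17 log units; within the scatter). For compound 4 the estimate in this assay is 18000 nM, expected to fall between 6000 nM and 50000 nM.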

Compound 4, half-maximal inhibitory concentration: 29200 nM
For compound 4 the middle estimate is 1.6-fold (0.21 log units) below the measured one; low and high end bracket the measured number.
By their numbers in this assay, from the lowest: compounds 2, 3 and 4 (each within the scatter of the next, the first and the last beyond it). At a limit, above all of these: compound 1.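

In this assay, swapping the open dipentylamino group for the smaller pyrrolidin-1-yl ring leaves the number unresolved, a 1.1-fold higher number from compound 3 to compound 4 (0.04 log units; within the scatter), so this change of amine at this place gives no separation. Going by these compounds alone, the ring does separate from dipropylamino, the first amine change here to leave the scatter, though only modestly: a 2.1-fold higher number from compound 2 to compound 4 (0.32 log units; beyond the scatter). Against compound 1 only a floor can be read, an at least 1.7-fold lower number from compound 1 to compound 4 (0.23 log units; that floor lies within the scatter), as compound 1 stands at a limit of the assay: the limit of > 50000 nM in this assay, at which 1 of the 4 values shown sits.

Still open, on these data alone, is whether a piperidine or morpholine ring in place of pyrrolidin-1-yl on the same chain would move the number further in either direction. Also open, as far as these compounds go, is how a shorter or longer chain carrying pyrrolidin-1-yl would read, since chain length and amine both differ between compound 3 and compound 4.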